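Aryl substituent swap, cyano to acetyl: lipophilicity notes

This account rests on a few compounds, and the source may have more. Where it says the series, first, only, none or still open, it means among the compounds named here.

Measured compounds:
compound 1 `CCOC(=O)c1ccc(/N=N/N(C)C(=O)[C@H](C)NC(C)=O)cc1` gives 2.52 in a physicochemical assay for lipophilicity, read by HPLC, in phosphate buffer, measured as octanol-water partition, at pH 7.4; on this read-out higher numbers stand for higher lipophilicity and lower numbers for lower lipophilicity
compound 2 `CCC(=O)N[C@@H](C)C(=O)N(C)/N=N/c1ccc(C#N)cc1` gives 1.87 in this assay
compound 3 `CC(=O)N[C@@H](C)C(=O)N(C)/N=N/c1ccc(C#N)cc1` gives 1.41 in this assay

Compound 3 stands lowest of the three numbers in this assay. Its nearest neighbour is compound 2, the gap being a number 0.46 log units lower from compound 2 to compound 3 (beyond the scatter); the furthest is compound 1, the gap being a number 1.11 log units lower from compound 1 to compound 3 (beyond the scatter).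

Compound 4 `CC(=O)N[C@@H](C)C(=O)N(C)/N=N/c1ccc(C(C)=O)cc1` differs from compound 3 by acetyl in place of cyano on an aromatic carbon. Going by the values given here, of the measured steps, only the one from compound 1 to compound 3 touches the same aromatic carbon; there, a number 1.11 log units lower from compound 1 to compound 3 (beyond the scatter). The step from compound 2 to compound 3 sits on the acyl chain and does not bear on this change. Among the compounds with values here, no measured step covers acetyl directly. The entering group carries one carbonyl and three heavy atoms against the two of the nitrile, so a small move upward in this assay is expected, though not beyond the scatter. For compound 4 the expected step is a number 0.14 log units higher from compound 3 to compound 4 (within the scatter). Compound 4 is therefore estimated at 1.55 in this assay, with a range from 1.15 to 1.95.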

Compound 4, partition coefficient: 1.51
For compound 4 the middle estimate is 0.04 log units above the measured one, within the range that was stated.
By their numbers in this assay, from the lowest: compounds 3 and 4 (each within the scatter of the next); then compound 2; then compound 1.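

At this aromatic carbon, para to a large group, acetyl and cyano are not separated by this assay: the swap gives a number 0.10 log units higher from compound 3 to compound 4 (within the scatter), so the two groups can stand in for each other on this read-out, at least on the shared core with the acetyl side chain. The other new step, with methyl in place of ethoxy on a carbonyl carbon, gives a number 1.01 log units lower from compound 1 to compound 4 (beyond the scatter); it is of the same large class as a number 1.11 log units lower from compound 1 to compound 3 (beyond the scatter), so among these three groups ethoxycarbonyl alone stands apart, and keeping a carbonyl at this carbon does not by itself retain the higher number of compound 1. Nothing at hand accounts for either step.

Open, as far as these compounds go, is how a carboxylic acid, an amine or a longer ester would read at the same aromatic carbon, and whether the three groups seen here mark the full range of this position. Also open, from the compounds shown here alone, is whether a number 0.46 log units lower from compound 2 to compound 3 (beyond the scatter), a step on the acyl chain, would carry over unchanged to a propanoyl analogue of compound 4.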